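From difluoromethyl to trifluoromethyl in compound 3

This account rests on a few compounds, and the source may have more. Where it says the series, first, only, none or still open, it means among the compounds named here.

In an ADME assay on microsomes from liver (Macaca fascicularis) for metabolic stability, read by LC-MS, with a stated time of 65 min, tested at 1 uM (a lower number here means that less of the compound is left, a higher number that more of the compound is left), compound 1 (`Fc1cc2nc(-c3cncnc3C(F)(F)F)n(C3CC3)c2cc1F`) gives 99%, and compound 2 (`N#Cc1ccc2nc(-c3cncnc3C(F)F)n(C3CC3)c2n1`) gives 101%. These two numbers lie within the usual scatter of each other, so compound 2 stands level with compound 1, with nearly all of the compound left at the end of the assay.

Compound 3 (`N#Cc1ccc2nc(-c3cncnc3C(F)(F)F)n(C3CC3)c2n1`) has not yet been measured. It differs from compound 2 in one place: fluoro in place of hydrogen on a saturated chain carbon bound to an aromatic carbon and two fluorine atoms. In words, this is fluoro in place of hydrogen on a saturated chain carbon bound to an aromatic carbon and two fluorine atoms, which also reads as difluoromethyl to trifluoromethyl.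

For the measured compounds named here, the measured compounds offer no single-place step to serve as a precedent for this change. No step beyond the scatter is expected in this assay, in either direction, since compound 2 already gives 101%. The expected size of the change is a number 3 percentage points lower from compound 2 to compound 3 (within the scatter), which would stay within the scatter. For compound 3 the estimated value is 98%, with an expected range from 87% to 106%.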

Compound 3, percent of the compound remaining: 87%
The estimate for compound 3 lay 11 percentage points above the measured number; the range from low to high includes it.
By their numbers in this assay, from the lowest: compound 3; then compounds 1 and 2 (each within the scatter of the next).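

In this assay, for the compounds shown here, fluoro in place of hydrogen on a saturated chain carbon bound to an aromatic carbon and two fluorine atoms gives a number 14 percentage points lower from compound 2 to compound 3 (beyond the scatter), the first single-place step, so this position is not silent in this read-out, even for a change of one atom. The step belongs to this pair alone: compound 1 also carries trifluoromethyl but differs from compound 3 in more than one place, so it cannot be read against this step, and trifluoromethyl cannot be said to lower the percent remaining in general. Nothing at hand accounts for the step, which stands here as an observation only.

Open, from the compounds shown here alone, is whether difluoromethyl to trifluoromethyl on the core of compound 1 would give a step of similar size, or any step beyond the usual scatter. Also open, going by these compounds, is how this assay would respond to other groups at this place, such as a methyl group, a longer chain or an amine, and so whether the step is particular to the added fluoro.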